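The compounds below may be only part of what the source reports. "The series", "measured", "known", "first", "only" and "open" are said of these compounds alone.

Measured compounds:
Compound 1 `O=S(=O)(c1ccc(F)c(Cl)c1)c1cnc2cc(F)ccc2c1-c1ccc(Cl)cc1`: 0.39 mL/min
Compound 2 `O=S(=O)(c1cc(Cl)cc(Cl)c1)c1cnc2cc(F)ccc2c1-c1ccc(Cl)cc1`: 0.13 mL/min
Compound 3 `O=S(=O)(c1cc(Cl)cc(Cl)c1)c1cnc2c(F)cccc2c1-c1ccc(F)cc1`: 1.01 mL/min

All three were tested in an ADME assay on microsomes from liver (Homo sapiens) for metabolic stability, tested at 2.5 uM; a lower number here means slower removal, a higher number faster removal of the compound. Compound 2 gives the lowest of the three numbers and compound 3 the highest, with compound 3 standing beyond the scatter from both compound 1 and compound 2. The difference between the core of compound 2 and the core of compound 3 is not broken down here. Compound 1 and compound 2 share a core and differ in one place only: 3-chloro-4-fluorophenyl in place of 3,5-dichlorophenyl on a sulfonyl sulfur. That change produced a 3.0-fold higher number from compound 2 to compound 1 (0.48 log units; beyond the scatter).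

Compound 4 `O=S(=O)(c1ccc(F)c(Cl)c1)c1cnc2c(F)cccc2c1-c1ccc(F)cc1` has not yet been measured in this assay. It is made from compound 3 by the same change, at the same kind of place: 3-chloro-4-fluorophenyl in place of 3,5-dichlorophenyl on a sulfonyl sulfur. Because the same change earlier gave a 3.0-fold higher number from compound 2 to compound 1 (0.48 log units; beyond the scatter), and compound 3 already stands at 1.01 mL/min, the step for compound 4 is expected to be of a similar size, a 2.6-fold higher number from compound 3 to compound 4 (0.41 log units; beyond the scatter). Among the measured compounds shown here, only one earlier instance of this change is known, so the range is kept wide. Compound 4 is therefore estimated at 2.6 mL/min, likely between 1.2 mL/min and 5.5 mL/min.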

Compound 4, intrinsic clearance in a liver preparation (reported as CLH), per the amount of preparation that the assay uses: 0.19 mL/min
Beside the measured number, compound 4's estimate is 14-fold (1.14 log units) above it, outside the stated range (below it).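

In this assay, placing 3-chloro-4-fluorophenyl in place of 3,5-dichlorophenyl on a sulfonyl sulfur gave a 5.3-fold lower number from compound 3 to compound 4 (0.73 log units; beyond the scatter), so the step seen on the core of compound 2 did not carry over to the core of compound 3, neither in direction nor in size: the same change on two cores in this assay, a 3.0-fold higher number (0.48 log units; beyond the scatter) from compound 2 to compound 1 and a 5.3-fold lower number (0.73 log units; beyond the scatter) from compound 3 to compound 4, 16-fold (1.20 log units) apart, beyond the scatter of two such steps For these two pairs, then, the outcome of this change depends on the core that carries it, and a step read on one core cannot simply be transferred to the other. What this does not show is which part of the difference between the two cores matters, and two pairs give no rule for any further core.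

The compounds shown leave open which way the change would go on a core that differs from these in only one place. They also leave open how this assay would read with a nitrile or a methoxy group on the ring attached to the sulfonyl sulfur, or with an amine there.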